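This account rests on a few compounds, and the source may have more. Where it says the series, first, only, none or still open, it means among the compounds named here.

Measured so far:
compound 1, `O=C(NC[C@@H]1CCCc2cc(S(=O)(=O)c3cccc(F)c3)ccc21)c1ncc[nH]1`, 15.9 nM in an assay on isolated protein for displacement of a labelled ligand from 5-hydroxytryptamine receptor 6 (Homo sapiens); on this read-out lower numbers stand for stronger inhibition and higher numbers for weaker inhibition;
compound 2, `O=S(=O)(c1cccc(F)c1)c1ccc2c(c1)CCC[C@H]2CNCCO`, 0.126 nM.

Going by the values given here, compound 2 holds the lowest of the two numbers; its nearest neighbour is compound 1, and the only step seen so far, a 130-fold lower number from compound 1 to compound 2 (2.10 log units; beyond the scatter), puts compound 2 far apart from it. Compound 3, `O=S(=O)(O)CCCNC[C@@H]1CCCc2cc(S(=O)(=O)c3cccc(F)c3)ccc21`, is not yet measured. It differs from compound 2 by sulfomethyl in place of hydroxy on a saturated chain carbon, two bonds along the chain from an amine nitrogen, a sulfomethyl in place of hydroxy on a saturated chain carbon, two bonds along the chain from an amine nitrogen. Among the compounds with values here, no measured step bears on this change: the one step available swaps the group on the amine nitrogen itself, not the end of the chain, so it gives little guidance. From the structures alone, a modest weakening is expected, and the estimated step is a 16-fold higher number from compound 2 to compound 3 (1.20 log units; beyond the scatter). Compound 3 is therefore estimated at 2 nM, within a range from 0.2 nM to 20 nM.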

Compound 3, inhibition constant: 1.26 nM
Compound 3: middle estimate off by 1.6-fold (0.20 log units), on the high side; low and high end bracket the measured number.
By their numbers in this assay, from the lowest: compound 2; then compound 3; then compound 1.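

In this assay, this position on the chain tolerates a large change of group: a 10-fold higher number from compound 2 to compound 3 (1.00 log units; beyond the scatter) is a modest loss, so the sulfomethyl group costs far less than replacing the whole 2-hydroxyethyl group with (1H-imidazol-2-yl)carbonyl did. The 3-sulfopropyl group also still beats that carbonyl group on the amine nitrogen, with a 13-fold lower number from compound 1 to compound 3 (1.10 log units; beyond the scatter), so the two chains shown both give lower numbers than the amide. No measurement here gives a reason for either step.

This change makes the chain longer and replaces its hydroxy group in a single move, so the compounds shown cannot separate those two effects. A 3-hydroxypropyl or 2-sulfoethyl group on the same amine nitrogen would pull them apart, and a carboxylic acid in place of the sulfo group would test how specific that group is.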